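A few compounds are considered here, and "the series" means these few. Any claim that something is new, unique, unknown or untested is made for them only; others in the source may bear on it.

Measured compounds:
- compound 1, `CCOC(=O)c1c(-c2ccc(Cl)cc2)cc(-c2ccccc2)nc1N1CCCCC1`: in a functional assay on the whole organism (strain Wister albino) for inhibition, with Rattus norvegicus as the target, read by paw edema, with stated times of 1 h and 3 h, at a dose of 50 mg/kg by the intraperitoneal route (a higher number here means more inhibition at the dose given (going by the name of the read-out), a lower number less inhibition), compound 1 gives 24%
- compound 2, `CCOC(=O)c1c(-c2ccc(Cl)c(Cl)c2)cc(-c2ccccc2)nc1N1CCCCC1`: in this assay compound 2 gives 46.3%

Going by the values given here, compound 2 holds the higher of the two numbers measured so far. Among the compounds with values here, its nearest neighbour is compound 1, and the single measured step, a number 22.3 percentage points higher from compound 1 to compound 2 (beyond the scatter), separates them. That step came from a chloro in place of hydrogen on an aromatic carbon, a change that leaves the rest of the shared core untouched.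

Compound 3, `CCOC(=O)c1c(-c2ccc(Cl)c(Cl)c2)cc(-c2ccccc2)nc1Nc1ccc(Cl)cc1`, is not yet measured. It differs from compound 2 in one place: (4-chlorophenyl)amino in place of piperidin-1-yl on an aromatic carbon. The group that leaves and the group that enters differ in kind, since a non-aromatic ring gives way to an aromatic one carrying a chlorine and a hydrogen-bond donor. Within the data shown here, no measured step tells what such an exchange does in this assay; the only step at hand concerns a different change on a different part of the molecule, so it gives no guide to direction or size here.

With nothing to lean on, the expected step of a number 0.3 percentage points lower from compound 2 to compound 3 (within the scatter) is taken to stay within the scatter. The estimate for compound 3 in this assay is therefore 46%, expected to fall between 25% and 67%.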

Compound 3, a percentage reported as inhibition, in the whole organism at one dose (the size of the read-out at that dose, not a potency): 62.2%
For compound 3 the middle estimate is 16.2 percentage points below the measured one; the measured number falls inside the stated range.
By their numbers in this assay, from the lowest: compound 1; then compound 2; then compound 3.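

Going by these compounds alone, this is the first view of the position next to the ring nitrogen, since the only earlier step was a chloro exchange elsewhere on the molecule. In this assay, the move to (4-chlorophenyl)amino gives a number 15.9 percentage points higher from compound 2 to compound 3 (beyond the scatter), so this position accepts a change in the kind of group, from a non-aromatic ring to an aromatic one joined through an amine, and the number still rises. The exchange alters several things at once, adding an aromatic ring, a chlorine and a hydrogen-bond donor, and nothing measured here explains the rise or assigns it to any one of these.

The compounds shown leave open how much of the rise belongs to the chlorine on the new ring and how much to the aromatic ring or the amine hydrogen, a question that phenylamino, without the chlorine, would help to separate. Going by these compounds, it also remains open whether a different non-aromatic ring, such as morpholin-4-yl, would behave like piperidin-1-yl at this position.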